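The source may report more compounds than this note shows. Statements on the series, on what has been measured and on what is new or still open speak of the compounds shown alone.

Compound 2 `CCOC/C=C/c1ccc(CN(C(=O)C2CCCCC2)c2cccc(/C=C/C(=O)OC)c2)cc1` stands at the high end of the two numbers seen so far: in an assay on isolated protein with Bile acid receptor (Homo sapiens) as the target (a higher number here means that more compound is needed for the effect, a lower number that less compound is needed), compound 2 gives 198000 nM, whereas compound 1 `COC(=O)/C=C/c1cccc(N(Cc2ccc(/C=C/c3cccc(F)c3)cc2)C(=O)C2CCCCC2)c1` gives 86 nM. Among the compounds with values here, the one measured step, a 2300-fold higher number from compound 1 to compound 2 (3.36 log units; beyond the scatter), replaced an aromatic group on the double-bonded chain carbon with a short chain bearing one oxygen and moved the number a long way upward.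

Compound 3 `COC(=O)/C=C/c1cccc(N(Cc2ccc(-c3ccc(OC(F)(F)F)cc3)cc2)C(=O)C2CCCCC2)c1` reverses the direction of that exchange: 4-(trifluoromethoxy)phenyl in place of 3-ethoxyprop-1-en-1-yl on an aromatic carbon. The chain that enters in compound 2 leaves again, and a six-membered aromatic ring carrying a trifluoromethoxy group enters on the aromatic carbon. Within the data shown here, the nearest comparison is compound 1, whose aryl-bearing chain gives 86 nM; no measured compound carries an aromatic ring bound directly to the ring at this place, so the match is not exact.

Given the size of a 2300-fold higher number from compound 1 to compound 2 (3.36 log units; beyond the scatter), a large downward step is expected for compound 3, a 660-fold lower number from compound 2 to compound 3 (2.82 log units; beyond the scatter), landing in the neighbourhood of compound 1 but with wide uncertainty. Compound 3 is therefore estimated at 300 nM in this assay, with a range of 40 nM to 3000 nM.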

Compound 3, half-maximal effective concentration: 264 nM
Compound 3: middle estimate off by 1.1-fold (0.06 log units), on the high side, within the range that was stated.
By their numbers in this assay, from the lowest: compound 1; then compound 3; then compound 2.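

In this assay, the aromatic carbon para to a large group accepts a six-membered aromatic ring bound directly, without the ethenyl link: putting 4-(trifluoromethoxy)phenyl in place of 3-ethoxyprop-1-en-1-yl gives a 750-fold lower number from compound 2 to compound 3 (2.88 log units; beyond the scatter). Exchanging 2-(3-fluorophenyl)ethenyl for the same group gives a much smaller change, a 3.1-fold higher number from compound 1 to compound 3 (0.49 log units; beyond the scatter), so among these three compounds both aryl-bearing groups stand far lower than the one open chain with its single oxygen, although the directly bound ring still stands above the ethenyl-linked one by more than the scatter. No measured evidence bears on the reason for either step.

The last exchange alters the link and the ring substituent together, so their separate shares in that modest step cannot be read, and an unsubstituted phenyl bound directly at this place would be needed to divide them. On these data alone, whether the poor value belongs to the ethoxy oxygen or to the absence of a ring also stays open, and a plain alkyl chain, an amine or a carboxylic acid at this place would address that.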